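Sulfone Chain Added to Compound 3: Expected Cytotoxicity

A few compounds are considered here, and "the series" means these few. Any claim that something is new, unique, unknown or untested is made for them only; others in the source may bear on it.

Compound 1 `O=c1n(Cc2nc3ccc(Cl)cn3c2CCCCO)c2cnccc2n1C1CC1` — > 100000 nM
Compound 2 `O=c1n(Cc2nc3cc(C(F)(F)F)ccn3c2CCCCO)c2cnccc2n1C1CC1` — > 100000 nM
Compound 3 `O=c1n(Cc2cn3ccc(Cl)cc3n2)c2cnccc2n1C1CC1` — 22300 nM

Three compounds were tested in an ADME assay on HEp-2 cells (Homo sapiens) for cytotoxicity, read by CCK-8 assay, with a stated time of 6 days; a higher number here means that more compound is tolerated, a lower number that less compound is tolerated. Compound 1 reaches only the limit of the assay, > 100000 nM. Compound 2 likewise sits at the limit, > 100000 nM. Going by the values given here, compound 3 is the only one with a number, giving 22300 nM in this assay. Among the compounds with values here, no two measured compounds differ in one place, so no single step is known.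

Compound 4 `CS(=O)(=O)CCc1c(Cn2c(=O)n(C3CC3)c3ccncc32)nc2cc(Cl)ccn12` differs from compound 3 by 2-(methylsulfonyl)ethyl in place of hydrogen on an aromatic carbon. With the limit of > 100000 nM in this assay, at which 2 of the 3 values shown sit, the set leans toward tolerated compounds, and a step upward in this assay of about a 2.7-fold higher number from compound 3 to compound 4 (0.43 log units; beyond the scatter) is expected for compound 4. Compound 4 is estimated at 60000 nM, between 20000 nM and 150000 nM.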

Compound 4, half-maximal cytotoxic concentration: > 100000 nM
Compound 4: no number, only a limit (the forecaster's own chance of this, stated with the estimate: 45%); middle value at least 1.6-fold (0.22 log units) from the limit.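

Placing 2-(methylsulfonyl)ethyl in place of hydrogen on this aromatic carbon gives the only single step shown in this assay, an at least 4.4-fold higher number from compound 3 to compound 4 (0.65 log units; beyond the scatter). This shows that a chain at this position can carry the chlorinated compound 3 from a measured value up to the limit of the assay, so the step is only a lower bound. The result for compound 4 lies at the limit shared by most of the set: the limit of > 100000 nM in this assay, at which 3 of the 4 values shown sit.

From the compounds shown here alone, how far compound 4 lies past that limit remains open. So does whether an amine or a carboxylic acid on the same carbon would shift the value in the same direction.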